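Phenylsulfonyl indoles: hydroxy to methylpiperazine at the benzo ring

The source may report more compounds than this note shows. Statements on the series, on what has been measured and on what is new or still open speak of the compounds shown alone.

Series notes. Compound 1 `O=S(=O)(c1ccccc1)n1ccc2c(O)cccc21` gives 108 nM in an assay on isolated protein for displacement of a labelled ligand from 5-hydroxytryptamine receptor 6 (Homo sapiens), read by scintillation counting, with a stated time of 1 h (a lower number here means a stronger inhibitor, a higher number a weaker inhibitor), the lowest of three inhibition constants. Compound 2 `COc1ccc2c(ccn2S(=O)(=O)c2ccccc2)c1` gives 127 nM in this assay, a number within the scatter of compound 1. Among the measured compounds shown here, compound 3 `CN(C)c1cn(S(=O)(=O)c2ccccc2)c2ccccc12` gives 474 nM in this assay, beyond the scatter from compound 1 and the highest number so far. Compound 4 `CN1CCN(c2cccc3c2ccn3S(=O)(=O)c2ccccc2)CC1` is not yet measured; it differs from compound 1 by 4-methylpiperazin-1-yl in place of hydroxy on an aromatic carbon. For the measured compounds named here, no measured pair shows this change, so its effect has no direct precedent here. A step of moderate size toward a lower number is expected from compound 1 to compound 4 in this assay, a 1.8-fold lower number from compound 1 to compound 4 (0.26 log units; within the scatter), with the direction uncertain. Compound 4 is estimated at 60 nM, between 12 nM and 300 nM.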

Compound 4, inhibition constant: 1 nM
For compound 4 the middle estimate is 60-fold (1.78 log units) above the measured one; measured number below the stated range.
By their numbers in this assay, from the lowest: compound 4; then compounds 1 and 2 (each within the scatter of the next); then compound 3.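

In this assay, among the compounds shown here, 4-methylpiperazin-1-yl in place of hydroxy on an aromatic carbon gives a 110-fold lower number from compound 1 to compound 4 (2.03 log units; beyond the scatter) and is the first single-place change readable. This position therefore accepts a group of 7 heavy atoms containing a six-membered non-aromatic ring, and the number falls rather than rises. Nothing available accounts for the size of this step. Still open, from the compounds shown here alone, is whether piperazin-1-yl without the methyl, or morpholin-4-yl, at this same carbon would give a similar number. Going by these compounds, the effect of 4-methylpiperazin-1-yl at other carbons of the aromatic ring also remains open.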